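Hydroxy gives way to hydrogen in compound 3

This account rests on a few compounds, and the source may have more. Where it says the series, first, only, none or still open, it means among the compounds named here.

- compound 1 `Cc1cn([C@H]2C[C@H](CF)[C@@H](CO)O2)c(=O)[nH]c1=O`: > 100 uM
- compound 2 `Cc1cn([C@@H]2O[C@H](CO)[C@@H](CO)[C@H]2O)c(=O)[nH]c1=O`: > 100 uM

In a functional assay on CCRF-CEM cells (Homo sapiens) for antiproliferative activity, with a stated time of 72 h (a higher number here means that more compound is needed for the effect, a lower number that less compound is needed), compound 2 gives > 100 uM, which is a limit of the assay and not a number. Compound 1 gives > 100 uM, which is likewise a limit. Compound 3 `Cc1cn([C@H]2C[C@H](CO)[C@@H](CO)O2)c(=O)[nH]c1=O` differs from compound 2 by hydrogen in place of hydroxy on a saturated ring carbon. Within the data shown here, no measured step shows the effect of such a change. With compound 2 at > 100 uM as the guide, no step beyond the scatter is expected in this assay, and another limit is likely. The expected step is a step that the limit leaves unreadable from compound 2 to compound 3. For compound 3 the estimated value is 130 uM, with an expected range of 50 uM to 400 uM.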

Compound 3, concentration for half-maximal effect: 1 uM
Compound 3: the middle estimate sits 130-fold (2.11 log units) above what was measured, outside the stated range (below it).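

In this assay, among these compounds, hydrogen in place of hydroxy on the saturated ring carbon gives an at least 100-fold lower number from compound 2 to compound 3 (2.00 log units; beyond the scatter), so this ring position, silent in the earlier compounds, decides whether activity appears. Hydroxy in place of fluoro on the saturated chain carbon bound to a saturated ring carbon gives an at least 100-fold lower number from compound 1 to compound 3 (2.00 log units; beyond the scatter), so the activity of compound 3 also depends on that hydroxy. Both steps start from a limit and not from a number: the limit of > 100 uM in this assay, at which 2 of the 3 values shown sit.

On these data alone, it remains open whether a methoxy group or an amine on the ring carbon would keep this activity. As far as these compounds go, it also remains open whether an amine could stand in for the hydroxy on the chain carbon.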